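The source may hold more compounds than are shown below. What is called first, only, known or untested is meant among the compounds shown, and "the series" means these compounds.

Of the compounds shown here, three built on a shared core have been tested in a functional assay on A549 cells (Homo sapiens) for inhibition, read by CCK-8 assay, with a stated time of 72 h, tested at 10 uM; a lower number here means a weaker effect, a higher number a stronger effect of the compound at the concentration tested. Compound 1 `CN(C)C(=O)c1cc2cnc(Nc3ccc(C(=O)NCCCN=C=S)cc3)nc2n1C1CCCC1` gives 103%. Compound 2 `CN(C)C(=O)c1cc2cnc(Nc3ccc(C(=O)NCCCCN=C=S)cc3)nc2n1C1CCCC1` gives 102%. Compound 3 `CN(C)C(=O)c1cc2cnc(Nc3ccc(NC(=O)CCCCCN=C=S)cc3)nc2n1C1CCCC1` gives 100%. Compound 4 `CN(C)C(=O)c1cc2cnc(Nc3ccc(NC(=O)CCCCCCN=C=S)cc3)nc2n1C1CCCC1` has not yet been measured, and its value is the open question here.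

The change from compound 1 to compound 2 is a group of 4 heavy atoms (2 carbon, 1 nitrogen, 1 sulfur; no ring) in place of a group of 3 heavy atoms (1 carbon, 1 nitrogen, 1 sulfur; no ring), on a saturated chain carbon, three bonds along the chain from an amide-type nitrogen and the step it made was a number 1 percentage points lower from compound 1 to compound 2 (within the scatter). Compound 3 differs from compound 1 in the group on its core by a group of 11 heavy atoms (7 carbon, 2 nitrogen, 1 oxygen, 1 sulfur; no ring) in place of a group of 9 heavy atoms (5 carbon, 2 nitrogen, 1 oxygen, 1 sulfur; no ring), on an aromatic carbon, with a step of a number 3 percentage points lower from compound 1 to compound 3 (within the scatter); between compound 2 and compound 3 the step is a number 2 percentage points lower from compound 2 to compound 3 (within the scatter). The change from compound 3 to compound 4 is a group of 4 heavy atoms (2 carbon, 1 nitrogen, 1 sulfur; no ring) in place of a group of 3 heavy atoms (1 carbon, 1 nitrogen, 1 sulfur; no ring), on a saturated chain carbon, five bonds along the chain from a carbonyl carbon. It is the same kind of change as that from compound 1 to compound 2, and it appears in two pairs among the compounds shown, but it is not the same change: in one pair the group sits three bonds along the chain from an amide-type nitrogen, in the other five bonds along the chain from a carbonyl carbon.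

Because the earlier step of a number 1 percentage points lower from compound 1 to compound 2 (within the scatter) lay within the scatter, the step from compound 3 to compound 4 in this assay is expected to be no change at the digits printed from compound 3 to compound 4 (within the scatter). Compound 4 is therefore estimated to give 100% in this assay, most likely between 91% and 108%.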

Compound 4, a percentage reported as inhibition, at one concentration (the size of the read-out at that concentration, not a potency): 102%
Estimate against measurement, compound 4: 2 percentage points below, within the range that was stated.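

In this assay the new step on the second core is a number 2 percentage points higher from compound 3 to compound 4 (within the scatter), and the two other new steps are no change at the digits printed from compound 2 to compound 4 (within the scatter) and a number 1 percentage points lower from compound 1 to compound 4 (within the scatter), so none of these comparisons separates the compounds. Set beside the earlier step, the same exchange of a group of 3 heavy atoms for one of 4 heavy atoms gives results that cannot be told apart in the two places where it sits: the same change on two cores in this assay, a number 1 percentage points lower (within the scatter) from compound 1 to compound 2 and a number 2 percentage points higher (within the scatter) from compound 3 to compound 4, 3 percentage points apart, within the scatter of two such steps This shows that, at this one concentration, the change carried from one core to the other without a difference that could be read, but it does not show that the change has no effect on either core, since a percentage at a single concentration is not a potency and compound 4, at 102%, sits with the others near the top of the read-out.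

On these data alone, how these compounds compare at lower concentrations, where a difference hidden here might appear, remains open. Also open, as far as these compounds go, is whether the same reading would hold with a much shorter or longer chain, or with an amine or a carboxylic acid at the end of the chain in place of the present end group.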